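Replacing Nitro with Methoxy on the Phenyl Ring

The compounds below may be only part of what the source reports. "The series", "measured", "known", "first", "only" and "open" are said of these compounds alone.

Measured so far:
compound 1, `COc1ccccc1Nc1nc(SCc2ccc(C(F)(F)F)cc2)nc2ccccc12`: in a functional assay on MDA-MB-231 cells (Homo sapiens) for cytotoxicity, read by MTT assay, with a stated time of 72 h (a higher number here means a weaker inhibitor, a lower number a stronger inhibitor), compound 1 gives a limit only, > 50000 nM
compound 2, `O=[N+]([O-])c1ccc(Nc2nc(SCc3ccc(C(F)(F)F)cc3)nc3ccccc23)cc1`: in this assay compound 2 gives 8670 nM

Compound 2 holds the only number shown; the result for compound 1 is a limit, (the limit of > 50000 nM in this assay, at which 1 of the 2 values shown sits). Among the compounds with values here, the step of an at least 5.7-fold lower number from compound 1 to compound 2 (0.76 log units; beyond the scatter) is the sole measured comparison. Compound 3, `COc1ccc(Nc2nc(SCc3ccc(C(F)(F)F)cc3)nc3ccccc23)cc1`, differs from compound 2 by methoxy in place of nitro on an aromatic carbon. This runs from nitro back toward methoxy, the kind of group carried by compound 1, so a weaker result is expected for compound 3, a 3.5-fold higher number from compound 2 to compound 3 (0.54 log units; beyond the scatter), quite possibly ending again at a limit. The estimate for compound 3 in this assay is 30000 nM, between 8000 nM and 60000 nM.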

Compound 3, half-maximal inhibitory concentration: 15700 nM
Compound 3: the middle estimate sits 1.9-fold (0.28 log units) above what was measured; the measured number falls inside the stated range.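

The 4-methoxyphenyl and 4-nitrophenyl compounds cannot be told apart in this assay: a 1.8-fold higher number from compound 2 to compound 3 (0.26 log units; within the scatter). With methoxy kept on the ring, 4-methoxyphenyl in place of 2-methoxyphenyl gives an at least 3.1-fold lower number from compound 1 to compound 3 (0.50 log units; beyond the scatter), so the move away from the limit does not need nitro. Compound 1 remains a limit and not a number: the limit of > 50000 nM in this assay, at which 1 of the 3 values shown sits.

Still open, from the compounds shown here alone, is whether an amine or a carboxylic acid in place of nitro on this aromatic carbon would shift the number beyond the scatter from compound 2.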